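The source may hold more compounds than are shown below. What is called first, only, known or untested is meant among the compounds shown, and "the series" means these compounds.

Series notes, cytotoxicity. Compound 3 `CCCCCCCCNc1nccnc1C(=O)NCc1ccccc1` is one of three compounds on a shared core. In an ADME assay on Vero cells (Chlorocebus sabaeus) for cytotoxicity, read by microscopy, with a stated time of 6 days (on this read-out lower numbers stand for higher toxicity in this test and higher numbers for lower toxicity in this test), compound 3 gives > 100000 nM, which is a limit of the assay and not a number. Compound 1 `CCCCCNc1cnc(C(=O)NCc2ccccc2)cn1` in this assay also gives > 100000 nM, again a limit. Compound 2 `CCCCCCNc1cncc(C(=O)NCc2ccccc2)n1` in this assay gives 100000 nM. Compound 3 thus sits at the limit of > 100000 nM in this assay, at which 2 of the 3 values shown sit. The unmeasured compound 4 `CCCCCCNc1nccnc1C(=O)NCc1ccccc1` differs from compound 3 by hydrogen in place of ethyl on a saturated chain carbon, six bonds along the chain from a nitrogen on an aromatic ring. Within the data shown here, no step between measured compounds is known, and the three values give no direction to work from. The step of a number no higher from compound 3 to compound 4 (the limit leaves the size open) is expected to be none beyond the scatter. Compound 4 is expected to give about 100000 nM, with a range from 50000 nM to 200000 nM.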

Compound 4, minimum cytotoxic concentration: > 100000 nM
Compound 4: no number, only a limit; the forecaster's own chance of this, stated with the estimate: 70%; the middle value sits exactly at the limit.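

Among these compounds, the values of compound 3 and compound 4 in this assay are both limits of the assay and not numbers, and no step between them can be read. The compounds shown leave open whether hydrogen in place of ethyl at this place on the chain changes the minimum cytotoxic concentration at all.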